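Three Limits and an Unmeasured 4-Methylphenyl Change

The source may report more compounds than this note shows. Statements on the series, on what has been measured and on what is new or still open speak of the compounds shown alone.

Measured in a functional assay on MDA-MB-231 cells (Homo sapiens) for inhibition, read by sulforhodamine B assay; on this read-out lower numbers stand for stronger inhibition and higher numbers for weaker inhibition:
Compound 1 `COC(=O)CC/C(C)=C/Cc1c(OC)c(C)c2c(c1OCC#CCN1CCN(c3ccc(C#N)cc3)CC1)C(=O)OC2`: > 50000 nM (a limit)
Compound 2 `COC(=O)CC/C(C)=C/Cc1c(OC)c(C)c2c(c1OCC#CCN1CCN(c3ccccc3OC)CC1)C(=O)OC2`: > 50000 nM (a limit)
Compound 3 `COC(=O)CC/C(C)=C/Cc1c(OC)c(C)c2c(c1OCC#CCN1CCN(C(=O)C3COc4ccccc4O3)CC1)C(=O)OC2`: > 50000 nM (a limit)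

Compound 3 gives no number, only a limit, at > 50000 nM. All the measured compounds share one position: the limit of > 50000 nM in this assay, at which 3 of the 3 values shown sit.

Compound 4 `COC(=O)CC/C(C)=C/Cc1c(OC)c(C)c2c(c1OCC#CCN1CCN(c3ccc(C)cc3)CC1)C(=O)OC2` carries 4-methylphenyl in place of (2,3-dihydro-1,4-benzodioxin-2-yl)carbonyl on an amine nitrogen in a ring.

Going by the values given here, three measured steps bear on this change, and none has a size: a step that the two limits leave unreadable from compound 1 to compound 3, a step that the two limits leave unreadable from compound 2 to compound 3 and a step that the two limits leave unreadable from compound 1 to compound 2. With 4-cyanophenyl on that nitrogen, compound 1 stays at a limit, > 50000 nM. With 2-methoxyphenyl there, compound 2 also stays at a limit, > 50000 nM. No readable step in either direction is therefore expected in this assay, and another limit is the likeliest result. The expected change is a step that the limit leaves unreadable from compound 3 to compound 4. For compound 4 the estimated value is 60000 nM, with an expected range of 20000 nM to 150000 nM.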

Compound 4, half-maximal inhibitory concentration: > 50000 nM
Compound 4 was reported as a limit; the forecaster's own chance of this, stated with the estimate: 85%; the middle value lies beyond the limit too.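

Compound 4 gives only a limit in this assay, > 50000 nM. Going by these compounds alone, no step to it from compound 1, compound 2 or compound 3 can be read. The compounds shown leave open what any group on that ring nitrogen does to inhibition, because all sit at one position: the limit of > 50000 nM in this assay, at which 4 of the 4 values shown sit.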